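The source may report more compounds than this note shows. Statements on the series, on what has been measured and on what is new or still open speak of the compounds shown alone.

Going by the values given here, compound 2 `CCCS(=O)(=O)Nc1ccc(F)c(C(=O)c2n[nH]c3ncc(-c4ccc(C(C)(C)C)cc4)cc23)c1F` stands at 46% in an assay for binding affinity to dual specificity mitogen-activated protein kinase kinase 4 (Homo sapiens), read by KINOMEscan, tested at 100 nM (on this read-out higher numbers stand for a weaker effect at the one concentration tested and lower numbers for a stronger effect), the higher of the two numbers so far; compound 1 `CCCS(=O)(=O)Nc1ccc(F)c(C(=O)c2n[nH]c3ncc(-c4cccc(N(C)C)c4)cc23)c1F` gives 26% in this assay. Among the compounds with values here, the one measured step, a number 20 percentage points higher from compound 1 to compound 2 (beyond the scatter), exchanges the whole aryl group attached to the shared core, so it is the only guide available.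

Compound 3 `CCCS(=O)(=O)Nc1ccc(F)c(C(=O)c2n[nH]c3ncc(-c4ccc([N+](=O)[O-])cc4)cc23)c1F` differs from compound 2 by nitro in place of tert-butyl on an aromatic carbon. Within the data shown here, no measured step replaces tert-butyl with nitro, and compound 1 carries neither group, so the measured step bears on the change only loosely, through the fact that swapping the substituent on this aryl group moved this assay by a modest amount. A step of similar or smaller size is therefore expected from compound 2 to compound 3, with the direction not fixed by the data; a slight move toward a lower number is taken as the working guess, because compound 2 sits at 46%, the upper of the two measured values. For compound 3 the expected value in this assay is 38%, with a range of 12% to 65%. The step of a number 8 percentage points lower from compound 2 to compound 3 (within the scatter) is thus estimated to lie within or just beyond the scatter.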

Compound 3, a percentage reported as activity, at one concentration (the size of the read-out at that concentration, not a potency): 4.2%
Compound 3: the middle estimate sits 33.8 percentage points above what was measured; measured number below the stated range.
By their numbers in this assay, from the lowest: compound 3; then compound 1; then compound 2.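

In this assay, the exchange of tert-butyl for nitro para to a large group produces a large step (a number 41.8 percentage points lower from compound 2 to compound 3 (beyond the scatter)), so this substituent can shift the read-out much further than the earlier comparison showed. The second comparison (a number 21.8 percentage points lower from compound 1 to compound 3 (beyond the scatter)) places the 4-nitrophenyl compound on the low side of 3-(dimethylamino)phenyl, while 4-(tert-butyl)phenyl lies on the high side, so changes to this aryl group can move the number in either direction, with compound 3 giving the lowest number of the three. Nothing available explains why the number moves in either direction.

Three compounds cannot show whether the low number is specific to nitro or would also appear with a nitrile, a carboxylic acid or a primary amine in the same place. The step between 3-(dimethylamino)phenyl and 4-nitrophenyl changes both the group and where it sits on the ring, and 3-nitrophenyl and 4-(dimethylamino)phenyl would be needed to separate those two changes.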